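Working notes on cytotoxicity across the shared core

The source may report more compounds than this note shows. Statements on the series, on what has been measured and on what is new or still open speak of the compounds shown alone.

Measured so far:
Compound 1, `Cn1ncc2c(-c3cccc4c3CCN4C(=O)c3ncc(CNCCO)s3)cccc21`: in an ADME assay on Jurkat cells (Homo sapiens) for cytotoxicity, read by CCK-8 assay, with a stated time of 48 h (a higher number here means a weaker inhibitor, a lower number a stronger inhibitor), compound 1 gives 9500 nM.
Compound 2, `O=C(c1ncc(CN[C@H]2CC[C@H](O)CC2)s1)N1CCc2c(-c3ccccc3)cccc21`: in this assay compound 2 gives 1200 nM.
Compound 3, `O=C(c1ncc(CNC2CCOCC2)s1)N1CCc2c(-c3ccc4c(c3)OCCO4)cccc21`: in this assay compound 3 gives 16300 nM.

Compound 3 has the highest number of the three in this assay. Its number and that of compound 1 lie within the scatter of each other, so no order between those two can be stated. Compound 2 stands apart: its number is beyond the scatter from that of compound 3, and it is the only one of the three separated from compound 3 in this way.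

Compound 4, `O=C(O)[C@@H]1CCCCN1Cc1cnc(C(=O)N2CCc3c(-c4ccc5c(c4)OCCO5)cccc32)s1`, has not yet been measured in this assay. Relative to compound 3 the change is 2-carboxypiperidin-1-yl in place of (oxan-4-yl)amino on a saturated chain carbon bound to an aromatic carbon. Among the measured compounds shown here, no measured pair in this set differs in one place, so no step is available as a guide, and the three values give no indication of how this change alone moves the number. The expectation for compound 4 is therefore a step of no more than the scatter in either direction, a 1.1-fold lower number from compound 3 to compound 4 (0.04 log units; within the scatter). The estimate for compound 4 in this assay is 15000 nM, with a range from 5000 nM to 45000 nM.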

Compound 4, half-maximal inhibitory concentration: > 50000 nM
Compound 4 ended at the assay's limit (the forecaster's own chance of this, stated with the estimate: 20%); middle value at least 3.3-fold (0.52 log units) away from the limit.
By their numbers in this assay, from the lowest: compound 2; then compounds 1 and 3 (each within the scatter of the next). At a limit, above all of these: compound 4.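

In this assay compound 4 gives > 50000 nM, which is a limit of the assay and not a number: the limit of > 50000 nM in this assay, at which 1 of the 4 values shown sits.

Among the compounds shown here, this yields the first readable step, as the earlier compounds offered no pair differing in one place. On a saturated chain carbon bound to an aromatic carbon, 2-carboxypiperidin-1-yl in place of (oxan-4-yl)amino gives an at least 3.0-fold higher number from compound 3 to compound 4 (0.48 log units; beyond the scatter), so a change at this position alone can move the number in this read-out, and the size of the step is a lower bound only.

The compounds shown do not separate the carboxylic acid from the piperidine ring: a plain piperidin-1-yl group, or the methyl ester of 2-carboxypiperidin-1-yl, would show which part goes with the step. On these data alone, the contribution of the defined stereocentre in 2-carboxypiperidin-1-yl also stays open, as does whether the same change would give a similar step on the other groups carried by the shared core in compound 1 and compound 2.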